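From compound 2 to compound 3: losing the hydroxy

The source may report more compounds than this note shows. Statements on the series, on what has been measured and on what is new or still open speak of the compounds shown alone.

Measured in a functional assay on A-375 cells (Homo sapiens) for inhibition, read by MTT assay, with a stated time of 48 h; on this read-out lower numbers stand for stronger inhibition and higher numbers for weaker inhibition:
compound 1 `OC(COc1ccc(-c2ccccc2)cc1)CN1CCN(c2ccccc2)CC1`: 14300 nM
compound 2 `OC(CNCc1ccc(-c2ccccc2)cc1)COc1cccc(Nc2ccccc2)c1`: 1980 nM

Of these two, compound 2 has the lower number, and the gap to compound 1 lies beyond the usual scatter. Compound 3 `c1ccc(Nc2cccc(OCCCNCc3ccc(-c4ccccc4)cc3)c2)cc1` has not yet been measured. Its structure departs from that of compound 2 by one change: hydrogen in place of hydroxy on a saturated chain carbon bound to two saturated chain carbons. Going by the values given here, no measured pair shows this change alone, and compound 1 differs from compound 2 in more than one place, so the data offer no direct guide. The estimate therefore stays close to compound 2 at 1980 nM. The expected move, a 1.1-fold lower number from compound 2 to compound 3 (0.04 log units; within the scatter), is none beyond the scatter in either direction. Compound 3 is expected at about 1800 nM, with an estimated range of 700 nM to 4800 nM.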

Compound 3, half-maximal inhibitory concentration: 2310 nM
Compound 3: the middle estimate sits 1.3-fold (0.11 log units) below what was measured; low and high end bracket the measured number.
By their numbers in this assay, from the lowest: compounds 2 and 3 (each within the scatter of the next); then compound 1.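

In this assay, putting hydrogen in place of hydroxy on a saturated chain carbon bound to two saturated chain carbons gives a 1.2-fold higher number from compound 2 to compound 3 (0.07 log units; within the scatter). Going by these compounds alone, this is the first comparison here in which only one place differs, which the gap between the two earlier compounds could not offer. For this pair, the hydroxy, with its hydrogen-bond donor and acceptor, can leave this position without a change beyond the scatter, and no independent measurement bears on the reason for this result.

From the compounds shown here alone, whether an amine or a carboxylic acid on this carbon, or a longer chain in place of this one, would also stay within the scatter of compound 2 remains open. Also open, going by these compounds, is whether the hydroxy could be lost with the same result from compound 1, which differs from compound 2 in more than one place.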